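Adding One Methyl to the Chain of Compound 3

The source may report more compounds than this note shows. Statements on the series, on what has been measured and on what is new or still open speak of the compounds shown alone.

In a functional assay on B16-F10 cells (Mus musculus) for antiproliferative activity, read by MTT assay, with a stated time of 72 h (a lower number here means a stronger inhibitor, a higher number a weaker inhibitor), compound 1 `CCCCCCCCCCNC[C@@H]1OC[C@H](N)[C@@H]1O` gives 29600 nM and compound 3 `CCCCCCCCCCCNC[C@@H]1OC[C@H](N)[C@@H]1O` gives 19300 nM. These two values lie within the scatter of each other. Compound 2 `CCCCCCCCNC[C@@H]1OC[C@H](N)[C@@H]1O` gives > 128000 nM, which is a limit of the assay and not a number. Compound 3 therefore stands level with compound 1, and the steps involving compound 2 are both beyond the scatter: an at least 4.3-fold higher number from compound 1 to compound 2 (0.63 log units; beyond the scatter) and an at least 6.6-fold lower number from compound 2 to compound 3 (0.82 log units; beyond the scatter).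

Compound 4 `CCCCCCCCCCCCNC[C@@H]1OC[C@H](N)[C@@H]1O` differs from compound 3 by methyl in place of hydrogen on a saturated chain carbon, ten or more bonds along the chain from an amine nitrogen, which is methyl in place of hydrogen on a saturated chain carbon, ten or more bonds along the chain from an amine nitrogen. For the measured compounds named here, the closest precedent is the identical change in a 1.5-fold lower number from compound 1 to compound 3 (0.19 log units; within the scatter), which stayed within the scatter. The larger steps involving compound 2 bear on it less directly. A similarly small shift towards a lower number is therefore expected in this assay, with no change beyond the scatter. The expected step is a 1.4-fold lower number from compound 3 to compound 4 (0.14 log units; within the scatter). For compound 4 the estimated value is 14000 nM, with an expected range of 7000 nM to 30000 nM.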

Compound 4, half-maximal inhibitory concentration: 10700 nM
Compound 4: middle estimate off by 1.3-fold (0.12 log units), on the high side, and the stated range covers the measured number.
By their numbers in this assay, from the lowest: compounds 4, 3 and 1 (each within the scatter of the next, the first and the last beyond it). At a limit, above all of these: compound 2.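

In this assay, the second single methyl added at this place on the chain again stays within the scatter, with a 1.8-fold lower number from compound 3 to compound 4 (0.26 log units; within the scatter). Read across both additions, the ethyl in place of hydrogen gives a 2.8-fold lower number from compound 1 to compound 4 (0.44 log units; beyond the scatter), the first gap beyond the scatter between two values that are both numbers, so small steps that cannot be told apart singly do separate over this span. The widest gap is an at least 11-fold lower number from compound 2 to compound 4 (1.07 log units; beyond the scatter), and it is a bound only, resting on a limit: the limit of > 128000 nM in this assay, at which 1 of the 4 values shown sits.

Going by these compounds, whether a longer chain would carry the numbers lower still, or whether they level off, stays open. So does the effect of a hydroxyl or a phenyl group in place of this methyl at the same place.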